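The source may hold more compounds than are shown below. What is called first, only, known or untested is meant among the compounds shown, and "the series" means these compounds.

Working notes on cytotoxicity in an ADME assay on MT2 cells (Homo sapiens) for cytotoxicity, read by XTT assay, with a stated time of 4 days; a lower number here means that less compound is tolerated, a higher number that more compound is tolerated. Within the data shown here, compound 2 `Cc1nc(C(NC(=O)C(=O)NC2CCCCCC2)C2CCCCN2)sc1CCO` gives 60000 nM, the only number in the set. Compound 3 `CC(=O)c1ccc(NC(=O)C(=O)NC(c2nc(C)c(CCO)s2)C2CCCCN2)cc1` returns a limit, > 48300 nM. Compound 1 `CC(=O)c1ccc(NC(=O)C(=O)NC(c2nc(C)c(CO)s2)C2CCCCN2)cc1` also returns a limit, > 107000 nM. Compound 3 differs from compound 1 by hydroxy in place of hydroxymethyl on a saturated chain carbon bound to an aromatic carbon; the step that the two limits leave unreadable from compound 3 to compound 1 is not readable, given the limit of > 48300 nM in this assay, at which 1 of the 3 values shown sits, and (the limit of > 107000 nM in this assay, at which 1 of the 3 values shown sits). The two cores differ by cycloheptyl in place of 4-acetylphenyl on an amide-type nitrogen; the step that the limit leaves unreadable from compound 2 to compound 3 is likewise not readable. Compound 4 `Cc1nc(C(NC(=O)C(=O)NC2CCCCCC2)C2CCCCN2)sc1CO` carries the same change as compound 1, on the core of compound 2: hydroxy in place of hydroxymethyl on a saturated chain carbon bound to an aromatic carbon, at the same place. With the measured step unreadable, the step of no change at the digits printed from compound 2 to compound 4 (within the scatter) in this assay is expected to be small, resting on compound 2 at 60000 nM as the only anchor. Compound 4 is therefore estimated at 60000 nM, expected between 30000 nM and 120000 nM.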

Compound 4, half-maximal cytotoxic concentration: > 90000 nM
Compound 4 gave a limit, no number (the forecaster's own chance of this, stated with the estimate: 30%); at least 1.5-fold (0.17 log units) between middle value and limit.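

With cycloheptyl on the amide-type nitrogen, the change from 2-hydroxyethyl to hydroxymethyl gives in this assay an at least 1.5-fold higher number from compound 2 to compound 4 (0.17 log units; that floor lies within the scatter). With 4-acetylphenyl in that place, the same change cannot be read, and neither can the other steps among these compounds, so nothing here shows that the change carries from one core to the other or that it fails to. Compound 4 gives a limit, > 90000 nM, so what stands for this step is a floor and not a size.

The compounds shown leave open how a 3-hydroxypropyl chain would read in this assay. They also leave open how an amine or a carboxylic acid would read in place of the hydroxy.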